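The source may hold more compounds than are shown below. What is called first, only, known or untested is meant among the compounds shown, and "the series" means these compounds.

Measured in a functional assay on B16-F10 cells (Mus musculus) for antiproliferative activity, read by MTT assay, with a stated time of 48 h; a lower number here means a stronger inhibitor, a higher number a weaker inhibitor:
- Compound 1 `Fc1ccc(NCc2cn(-c3ccccc3)nc2-c2ccc(Cl)cc2)cc1`: 2120 nM
- Compound 2 `Clc1ccc(NCc2cn(-c3ccccc3)nc2-c2ccc(Cl)cc2)cc1`: 2450 nM

These two values lie within the usual scatter of each other, so neither compound can be ranked above the other. Compound 3 `Clc1ccc(NCc2cn(-c3ccccc3)nc2-c2ccc(Br)cc2)cc1` keeps the rest of compound 2 but turns the 4-chlorophenyl into 4-bromophenyl: bromo in place of chloro on an aromatic carbon. Among the compounds with values here, only one measured step offers any guide. That step, a 1.2-fold higher number from compound 1 to compound 2 (0.06 log units; within the scatter), also exchanged one halogen for another, although at a different place in the molecule, so it bears on this change only loosely. Since that exchange made no clear difference, no shift beyond the scatter is expected in this assay, in either direction. The expected change is a 1.0-fold lower number from compound 2 to compound 3 (0.01 log units; within the scatter). Compound 3 is estimated at 2400 nM, with an expected range of 1300 nM to 4500 nM.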

Compound 3, half-maximal inhibitory concentration: 4290 nM
Beside the measured number, compound 3's estimate is 1.8-fold (0.25 log units) below it; low and high end bracket the measured number.
By their numbers in this assay, from the lowest: compounds 1, 2 and 3 (each within the scatter of the next, the first and the last beyond it).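

Compound 3 is the first compound shown in which the 4-chlorophenyl itself is altered, since the earlier pair differed at another place in the molecule. In this assay, putting bromo in place of chloro on this ring gives a 1.8-fold higher number from compound 2 to compound 3 (0.24 log units; within the scatter), so the two halogens cannot be told apart at this position, and bromo is accepted here as well as chloro. Nothing available explains this result at the level of the molecule.

All the compounds shown carry a halogen at this position, so they leave open how a group of a different kind, such as an amine or a carboxylic acid, would read in this assay. They also leave open what a plain unsubstituted phenyl would give there.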